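The source may hold more compounds than are shown below. What is called first, only, known or untested is meant among the compounds shown, and "the series" means these compounds.

Compound 1 `CN1CCN(c2ccc(-c3cc4c(N5CCN(S(=O)(=O)N6CCCCC6)CC5)ncnc4s3)cc2)CC1` gives 8130 nM
Compound 2 `CCCNC(=O)N1CCN(c2ncnc3sc(-c4ccc(N5CCN(C)CC5)cc4)cc23)CC1` gives 8330 nM
Compound 3 `CN1CCN(c2ccc(-c3cc4c(N5CCN(C(=O)Nc6ccccc6)CC5)ncnc4s3)cc2)CC1` gives 7590 nM

These three values come from a functional assay on MDA-MB-231 cells (Homo sapiens) for antiproliferative activity, read by MTT assay, with a stated time of 48 h; on this read-out higher numbers stand for weaker inhibition and lower numbers for stronger inhibition. Compound 3 stands level with the other two, since a 1.1-fold lower number from compound 1 to compound 3 (0.03 log units; within the scatter) and a 1.1-fold lower number from compound 2 to compound 3 (0.04 log units; within the scatter) are both within the scatter. Compound 4 `COc1ccc(NC(=O)N2CCN(c3ncnc4sc(-c5ccc(N6CCN(C)CC6)cc5)cc34)CC2)cc1` differs from compound 3 in one place, with methoxy in place of hydrogen on an aromatic carbon, so that phenylcarbamoyl becomes (4-methoxyphenyl)carbamoyl: methoxy in place of hydrogen on an aromatic carbon. Within the data shown here, no measured pair tests a methoxy group directly. The closest evidence is a 1.1-fold lower number from compound 2 to compound 3 (0.04 log units; within the scatter), a change on the same amide-type nitrogen. The wider exchanges, a 1.0-fold higher number from compound 1 to compound 2 (0.01 log units; within the scatter) and a 1.1-fold lower number from compound 1 to compound 3 (0.03 log units; within the scatter), were also within the scatter. Among the measured compounds shown here, on that evidence, a shift beyond the scatter in this assay is not expected in either direction, though this rests on only three compounds. The expected change is a 1.0-fold lower number from compound 3 to compound 4 (0.01 log units; within the scatter) and is estimated to stay within the scatter. For compound 4 the estimated value is 7500 nM, with an expected range from 3500 nM to 13000 nM.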

Compound 4, half-maximal inhibitory concentration: 20900 nM
The estimate for compound 4 lay 2.8-fold (0.45 log units) below the measured number; measured number above the stated range.
By their numbers in this assay, from the lowest: compounds 3, 1 and 2 (each within the scatter of the next); then compound 4.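

In this assay, among these compounds, methoxy in place of hydrogen on the six-membered aromatic ring, para to a large group, gives a 2.8-fold higher number from compound 3 to compound 4 (0.44 log units; beyond the scatter) and is the first step in this set to lie beyond the scatter. Compound 4 also separates from the other two compounds, with a 2.5-fold higher number from compound 2 to compound 4 (0.40 log units; beyond the scatter) and a 2.6-fold higher number from compound 1 to compound 4 (0.41 log units; beyond the scatter) as the printed steps, so the group on this nitrogen can change the number even though phenyl in place of propyl left it within the scatter. The data offer no measurement that accounts for this rise.

Methoxy is the only group shown on this ring, so it stays open whether the rise belongs to methoxy alone. A hydroxyl, an amine or a chlorine at the same place could show whether other groups move the number the same way.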